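The compounds below may be only part of what the source reports. "The series", "measured", "known", "first", "only" and "open" are said of these compounds alone.

Measured so far in an assay on HEK293 cells for positive allosteric modulation of metabotropic glutamate receptor 5 (Homo sapiens), read by FLIPR; a higher number here means that more compound is needed for the effect, a lower number that less compound is needed:

compound 1, `Cc1cccc(-c2noc(C3CN(C(=O)C4CCC(C(F)(F)F)CC4)C3)n2)c1`: 1000 nM
compound 2, `CC1CCC(C(=O)N2CC(c3nc(-c4cccc(Cl)c4)no3)C2)CC1`: 1500 nM
compound 3, `Cc1ccc(S(=O)(=O)N2CC(c3nc(-c4cccc(C)c4)no3)C2)cc1`: > 10000 nM

Compound 3 reaches only the limit of this assay, (the limit of > 10000 nM in this assay, at which 1 of the 3 values shown sits), so for it there is a limit and not a number. Of the two compounds with numbers, compound 2 and compound 1 sit within the usual scatter of each other in this assay, so neither can be called the more potent; compound 2 simply stands on the side of the pair that needs a little more compound.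

The step to be followed leads from compound 2 to compound 4, `CC1CN(C(=O)N2CC(c3nc(-c4cccc(Cl)c4)no3)C2)CC(C)O1`. The change is counted as 2,6-dimethylmorpholin-4-yl in place of 4-methylcyclohexyl on a carbonyl carbon

The carbonyl carbon keeps its amide-type nitrogen in a ring on one side; what sits on its other side is exchanged. Among the measured compounds shown here, no measured step in this set changes a group on that carbonyl carbon, so the size and direction of the step can only be expected, not read off. Because compound 3, whose carbonyl is replaced altogether, gives > 10000 nM, a change on this part of the molecule can clearly matter, and the entering ring with a hetero atom differs more from the leaving one than a small trim would. The estimate for compound 4 in this assay is therefore a step of a 2.0-fold higher number from compound 2 to compound 4 (0.30 log units; within the scatter) toward a higher number, with compound 4 expected at 3000 nM, in a range from 1000 nM to 10000 nM.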

Compound 4, half-maximal effective concentration: > 10000 nM
Compound 4: no number, only a limit (the forecaster's own chance of this, stated with the estimate: 25%); middle value at least 3.3-fold (0.52 log units) from the limit.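

Among the compounds shown here, this is the first readable step on the carbonyl carbon, and it shows that the group held there is not freely exchangeable: 2,6-dimethylmorpholin-4-yl in place of 4-methylcyclohexyl gives an at least 6.6-fold higher number from compound 2 to compound 4 (0.82 log units; beyond the scatter). The two rings are both six-membered and carry no net charge, yet the entering ring has a nitrogen attached to the carbonyl carbon, an oxygen and a hydrogen-bond acceptor that the leaving ring lacks, so similar ring size alone does not keep the compound within reach of a measured value. In this assay, compound 4 gives only a limit and not a number, so the step has a lower bound and its full size stays unknown: the limit of > 10000 nM in this assay, at which 2 of the 4 values shown sit.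

For the compounds shown here, the single step changes several things at once and cannot say which of them matters, whether the ring oxygen, the ring nitrogen or the two methyl groups. A 4-methylpiperidin-1-yl group, which keeps the nitrogen but has no oxygen, and a plain morpholin-4-yl group, which has no methyl groups, would each separate part of this on the same carbonyl carbon.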